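This account rests on a few compounds, and the source may have more. Where it says the series, first, only, none or still open, it means among the compounds named here.

Measured so far in an assay on cells for positive allosteric modulation of Cystic fibrosis transmembrane conductance regulator variant G551D (Homo sapiens), with stated times of 10 min and 2 min, in the presence of a further agent that is not named here; on this read-out higher numbers stand for an effect only at larger amounts of compound and lower numbers for an effect already at smaller amounts:
compound 1 `CC1(C)Cc2c(sc(NC(=O)c3ccn[nH]3)c2C(N)=O)C(C)(C)O1`, 339 nM
compound 2 `CC1(C)Cc2c(sc(NC(=O)[C@@H](O)C(C)(C)C)c2C(N)=O)C(C)(C)O1`, 421 nM

Compound 2 and compound 1 lie within the scatter of each other, as a 1.2-fold higher number from compound 1 to compound 2 (0.09 log units; within the scatter) shows; compound 2 is nearest to compound 1 and to nothing else. Compound 3 `CC1(C)Cc2c(sc(NC(=O)[C@H](O)C(C)(C)C)c2C(N)=O)C(C)(C)O1` differs from compound 2 by the two compounds have the same atoms and bonds and differ only in configuration as drawn: 1 of 1 stereo elements differ; a stereocentre at a saturated chain carbon is drawn S in compound 2 and R in compound 3. Within the data shown here, the one measured step exchanges the group on the carbonyl carbon and does not bear on a change of configuration; no measured step does, so neither size nor direction can be read from the series. The expected step of a 1.4-fold higher number from compound 2 to compound 3 (0.15 log units; within the scatter) is therefore centred within the scatter, with a wide range either way. Compound 3 is estimated at 600 nM, between 150 nM and 3000 nM.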

Compound 3, half-maximal effective concentration: 7780 nM
The estimate for compound 3 lay 13-fold (1.11 log units) below the measured number; the whole stated range lies below it.
By their numbers in this assay, from the lowest: compounds 1 and 2 (each within the scatter of the next); then compound 3.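

In this assay, configuration at this saturated chain carbon matters: going from S to R gives an 18-fold higher number from compound 2 to compound 3 (1.27 log units; beyond the scatter). The exchange of 1H-pyrazol-5-yl for 1-hydroxy-2,2-dimethylpropyl lay within the scatter with the S form, but with the R form it gives a 23-fold higher number from compound 1 to compound 3 (1.36 log units; beyond the scatter), so that exchange can be read only with its configuration stated. The gap can be assigned to this stereocentre alone because nothing else separates the pair: the fact that compounds 2 and 3 differ only in the configuration as drawn

Open, on these data alone, is whether an amine in place of the hydroxy group would keep a gap of this size between the S and R forms. Also open, as far as these compounds go, is whether the hydroxy group itself contributes to the number of compound 2.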